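Moving the Bromine Around the Phenyl Ring

The compounds below may be only part of what the source reports. "The series", "measured", "known", "first", "only" and "open" are said of these compounds alone.

Measured compounds:
compound 1, `N#CC1=C(N)Oc2c(c3nc4ccccc4nc3c3ccccc23)C12C(=O)N(Cc1cnnn1-c1ccccc1Br)c1ccccc12`: > 50000 nM
compound 2, `N#CC1=C(N)Oc2c(c3nc4ccccc4nc3c3ccccc23)C12C(=O)N(Cc1cnnn1-c1cccc(Br)c1)c1ccccc12`: > 50000 nM
compound 3, `N#CC1=C(N)Oc2c(N)cc3nc4ccccc4nc3c2C12C(=O)N(Cc1cnnn1-c1cccc(Br)c1)c1ccccc12`: > 50000 nM

All three measured compounds were tested in an ADME assay on L02 cells (Homo sapiens) for antiproliferative activity, read by MTT assay, with a stated time of 48 h; on this read-out higher numbers stand for weaker inhibition and lower numbers for stronger inhibition. Compound 1 gives > 50000 nM, which is a limit of the assay rather than a number. Compound 2 gives > 50000 nM, again only a limit. Compound 3 gives > 50000 nM, also a limit.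

Compound 2 and compound 1 differ in a single place: 2-bromophenyl in place of 3-bromophenyl on an aromatic nitrogen. The step that the two limits leave unreadable from compound 2 to compound 1 cannot be read in size, because the limit of > 50000 nM in this assay, at which 3 of the 3 values shown sit, holds both of its compounds.

Compound 3 differs from compound 2 in more than one place; how the two cores differ is not broken down here.

Compound 4, `N#CC1=C(N)Oc2c(N)cc3nc4ccccc4nc3c2C12C(=O)N(Cc1cnnn1-c1ccccc1Br)c1ccccc12`, has not yet been measured. It stands to compound 3 as compound 1 stands to compound 2: 2-bromophenyl in place of 3-bromophenyl on an aromatic nitrogen. The surroundings of the change are described in the same words for both pairs, so it is the same change made on a different core.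

For compound 4 the step that the limit leaves unreadable from compound 3 to compound 4 is expected to be no larger than the scatter, because the limit of > 50000 nM in this assay, at which 3 of the 3 values shown sit, shows that the same change left compound 2 and compound 1 together at the limit. Compound 4 is therefore estimated at 80000 nM, with a range from 30000 nM to 300000 nM, and the assay is expected most likely to report only a limit again.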

Compound 4, half-maximal inhibitory concentration: 29200 nM
Estimate against measurement, compound 4: 2.7-fold (0.44 log units) above, outside the stated range (below it).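

In this assay, replacing 3-bromophenyl with 2-bromophenyl gives an at least 1.7-fold lower number from compound 3 to compound 4 (0.23 log units; that floor lies within the scatter), and this is the only step among the compounds shown that has a readable size, though only as a floor. The same change on the other core cannot be sized, and so the two cores cannot be compared step for step, because compound 2 and compound 1 both sit at a limit: the limit of > 50000 nM in this assay, at which 3 of the 4 values shown sit. What the result does show is that the change is compatible with a measured number on one core, while it does not show that the change acts alike on both cores, nor, with a floor that lies within the scatter, that it gives a real gain in inhibition even on the core of compound 4.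

The compounds shown leave open whether the bromine itself matters, as a plain phenyl, a 2-chlorophenyl or a 2-methoxyphenyl group in the same place would test on the core of compound 4. Going by these compounds, compound 3 has only a limit, so the full size of the step also stays open.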